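Swapping a Pyridine Amide for a Difluorophenyl Amide

A few compounds are considered here, and "the series" means these few. Any claim that something is new, unique, unknown or untested is made for them only; others in the source may bear on it.

This study follows how strongly a small set of amide-bearing compounds slow the growth of a cancer cell line, measured in a functional assay on SK-BR-3 cells (Homo sapiens) for antiproliferative activity, read by MTT assay, with a stated time of 72 h; on this read-out lower numbers stand for stronger inhibition and higher numbers for weaker inhibition. Of the compounds shown here, two have numbers so far. Compound 1 `CCN1CCN(c2cc(C)c3cc(NC(=O)c4cccnc4)ccc3n2)CC1` carries a pyridin-3-yl group on its amide carbonyl, and in this assay compound 1 gives 10600 nM. Compound 2 `CCN(CC)c1cc(C)c2cc(NC(=O)c3ccc(Cl)c(Cl)c3)ccc2n1` shares the same core but differs from compound 1 in more than one place, and compound 2 gives 41200 nM. Compound 1 therefore has the lower of the two numbers, and the gap between them lies beyond the usual scatter.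

Compound 3 `CCN1CCN(c2cc(C)c3cc(NC(=O)c4ccc(F)c(F)c4)ccc3n2)CC1` keeps everything of compound 1 except the group on the amide carbonyl, where the change is 3,4-difluorophenyl in place of pyridin-3-yl on a carbonyl carbon. For the measured compounds named here, no measured pair shows this swap on its own, so the size of its effect is open. In this assay the change is expected to be a 1.4-fold higher number from compound 1 to compound 3 (0.15 log units; within the scatter), with its direction uncertain. Compound 3 is expected to give near 15000 nM in this assay, within a range from 5000 nM to 45000 nM.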

Compound 3, half-maximal inhibitory concentration: 1980 nM
Beside the measured number, compound 3's estimate is 7.6-fold (0.88 log units) above it; the whole stated range lies above it.
By their numbers in this assay, from the lowest: compound 3; then compound 1; then compound 2.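

In this assay, the step from pyridin-3-yl to 3,4-difluorophenyl on a carbonyl carbon gives a 5.4-fold lower number from compound 1 to compound 3 (0.73 log units; beyond the scatter), while the rest of the structure stays the same. This shows that the group on the amide carbonyl can by itself shift the number beyond the usual scatter, something the earlier pair could not reveal, as compound 1 and compound 2 differ in more than one place. The change removes a ring nitrogen and brings in a carbon-only ring bearing fluorine, but no measurement shown explains why the number falls.

This single step cannot say whether the loss of the ring nitrogen, the arrival of the fluorines, or both together account for the shift, and a plain phenyl or a 4-fluorophenyl group on the same carbonyl would help to separate these parts. It also leaves open how far this trend extends to other kinds of group at this position, such as a 4-aminophenyl or a 4-carboxyphenyl ring, and whether the same swap would act alike on a different amine at the other end of the shared core.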